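Cyclopropyl for vinyl on the amide side chain

A few compounds are considered here, and "the series" means these few. Any claim that something is new, unique, unknown or untested is made for them only; others in the source may bear on it.

Compound 1 `Cc1cc(C)c(N2CCCn3c2nc(C)c3C(=O)N(CC2CC2)CC2CC2)c(C)c1` carries a bis(cyclopropylmethyl)amino group on the carbonyl carbon, and in an in vitro assay on IMR-32 cells for displacement of a labelled ligand from corticotropin-releasing factor receptor 1 (Homo sapiens) (a lower number here means a stronger inhibitor, a higher number a weaker inhibitor), compound 1 gives 3400 nM. Compound 2 `C=CCN(CCC)C(=O)c1c(C)nc2n1CCCN2c1c(C)cc(C)cc1C` carries allyl(propyl)amino in its place. In this assay compound 2 gives > 5000 nM, which is a limit of the assay and not a number. Of the two values shown, compound 2 is the one sitting at the limit of > 5000 nM in this assay, at which 1 of the 2 values shown sits. The step of an at least 1.4-fold higher number from compound 1 to compound 2 (0.16 log units; that floor lies within the scatter) thus sets only a floor on how far apart the two compounds lie. Compound 3 `CCCN(CC1CC1)C(=O)c1c(C)nc2n1CCCN2c1c(C)cc(C)cc1C` differs from compound 2 by cyclopropyl in place of vinyl on a saturated chain carbon bound to an amide-type nitrogen, so its amide substituent stands midway between those of compound 1 and compound 2. Among the measured compounds shown here, the only measured step that bears on this change is an at least 1.4-fold higher number from compound 1 to compound 2 (0.16 log units; that floor lies within the scatter), and its floor does not reach beyond the scatter. For compound 3 the step of a number no higher from compound 2 to compound 3 (the limit leaves the size open) is expected to stay within the scatter, leaning toward compound 1. Compound 3 is estimated at 5000 nM, within 2500 nM to 10000 nM.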

Compound 3, inhibition constant: > 5000 nM
Compound 3: only a limit was reported; the forecaster's own chance of this, stated with the estimate: 50%; the middle value lies on the limit itself.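

In this assay compound 3 gives > 5000 nM, which is a limit of the assay and not a number, so cyclopropyl in place of vinyl on this saturated chain carbon brings no reading into range, and the step between the two limits cannot be read. With ethyl in place of cyclopropyl on the same kind of carbon, the only readable result is an at least 1.4-fold higher number from compound 1 to compound 3 (0.16 log units; that floor lies within the scatter). Compound 1 therefore remains the only one of the three with a number, while the other two sit together at one limit: the limit of > 5000 nM in this assay, at which 2 of the 3 values shown sit.

As far as these compounds go, how far compound 2 and compound 3 lie past that limit stays open, as does whether either truly parts from compound 1 by more than the scatter. Also open, from the compounds shown here alone, is whether a butyl chain or a methoxyethyl group on the amide nitrogen would give a readable number.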